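The compounds below may be only part of what the source reports. "The series", "measured", "known", "first", "only" and "open" are said of these compounds alone.

In an ADME assay on HaCaT cells (Homo sapiens) for cytotoxicity, read by MTT assay, with a stated time of 48 h (a higher number here means a weaker inhibitor, a lower number a stronger inhibitor), compound 2 `COc1ccc(-c2nn(-c3ccccc3)cc2-c2nc3cc(OC)ccc3[nH]2)cc1` gives > 50000 nM, which is a limit of the assay and not a number. Compound 1 `O=C(OCc1ccccc1)c1ccc2[nH]c(-c3cn(-c4ccccc4)nc3-c3ccc(F)cc3)nc2c1` gives > 50000 nM, also only a limit. Compound 2 therefore stands with compound 1 at the limit of > 50000 nM in this assay, at which 2 of the 2 values shown sit. Compound 3 `COc1ccc(-c2nn(-c3ccccc3)cc2-c2nc3cc(C(=O)OCc4ccccc4)ccc3[nH]2)cc1` departs from compound 2 in one place, with benzyloxycarbonyl in place of methoxy on an aromatic carbon. Compound 1 also carries benzyloxycarbonyl, yet its result in this assay remains the limit > 50000 nM. Among the measured compounds shown here, no measured step connects these compounds, so the expectation rests on those two limits alone. The expected change a number no higher from compound 2 to compound 3 (the limit leaves the size open) is none beyond the scatter, in either direction. For compound 3 the estimated half-maximal inhibitory concentration is 50000 nM, with an expected range from 25000 nM to 100000 nM.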

Compound 3, half-maximal inhibitory concentration: > 50000 nM
Compound 3 gave a limit, no number; the forecaster's own chance of this, stated with the estimate: 85%; the middle value lies on the limit itself.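

In this assay, among the compounds shown here, compound 3 gives > 50000 nM, a limit and not a number, so no step from compound 1 or compound 2 to compound 3 can be read. The compounds shown leave open whether benzyloxycarbonyl in place of methoxy changes the half-maximal inhibitory concentration at all: the limit of > 50000 nM in this assay, at which 3 of the 3 values shown sit.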